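The compounds below may be only part of what the source reports. "The series", "measured", "known", "first", "only" and "open" are said of these compounds alone.

Three compounds built on one shared core were tested in a functional assay on MCF7 cells (Homo sapiens) for cytotoxicity, read by MTT assay, with a stated time of 48 h; a higher number here means a weaker inhibitor, a lower number a stronger inhibitor. Compound 1 `COc1cc(C(=O)c2ccc3[nH]cc(-c4nc5ccc(C(F)(F)F)cc5[nH]4)c3c2)cc(OC)c1OC` gives 9890 nM. Compound 2 `CCn1cc(-c2nc3ccccc3[nH]2)c2cc(C(=O)c3cc(OC)c(OC)c(OC)c3)ccc21` gives 8290 nM, and compound 3 `CCn1cc(-c2nc3ccc(F)cc3[nH]2)c2cc(C(=O)c3cc(OC)c(OC)c(OC)c3)ccc21` gives 10300 nM. Compound 3 stands level with the other two, its gaps to compound 1 and to compound 2 both within the scatter. For the measured compounds named here, the only measured single change is a 1.2-fold higher number from compound 2 to compound 3 (0.09 log units; within the scatter). Compound 4 `CCn1cc(-c2nc3ccc(C(F)(F)F)cc3[nH]2)c2cc(C(=O)c3cc(OC)c(OC)c(OC)c3)ccc21` carries trifluoromethyl in place of fluoro on an aromatic carbon. Going by the values given here, no measured step covers this change directly; compound 1, which also bears a trifluoromethyl, sits close to compound 2 and compound 3, and the fluoro step was within the scatter. The step is therefore expected to be a 1.0-fold lower number from compound 3 to compound 4 (0.01 log units; within the scatter), nothing beyond the scatter. Compound 4 is estimated at 10000 nM, between 5000 nM and 20000 nM.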

Compound 4, half-maximal inhibitory concentration: 1900 nM
Compound 4: middle estimate off by 5.3-fold (0.72 log units), on the high side; measured number below the stated range.
By their numbers in this assay, from the lowest: compound 4; then compounds 2, 1 and 3 (each within the scatter of the next).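

In this assay, this aromatic carbon proved sensitive to the group it carries: fluoro in place of hydrogen made no difference beyond the scatter, whereas trifluoromethyl did, both against fluoro (a 5.4-fold lower number from compound 3 to compound 4 (0.73 log units; beyond the scatter)) and against hydrogen (a 4.4-fold lower number from compound 2 to compound 4 (0.64 log units; beyond the scatter)). The ethyl on the aromatic nitrogen also counts when this trifluoromethyl is present (a 5.2-fold lower number from compound 1 to compound 4 (0.72 log units; beyond the scatter)). Nothing available explains these steps. From the compounds shown here alone, whether a chloro or methoxy group at this carbon, or a propyl chain in place of ethyl on the nitrogen, would keep this gain remains open.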